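The source may hold more compounds than are shown below. What is called first, only, known or untested is meant among the compounds shown, and "the series" means these compounds.

Measured compounds in a functional assay on A549 cells (Homo sapiens) for antiproliferative activity; a higher number here means that more compound is needed for the effect, a lower number that less compound is needed:
- compound 1 `CCCCCCCCCCCCO/N=C/c1cc(OC)c2c(c1OC)C(=O)C=CC2=O`; value > 10 ug/mL, a limit of the assay
- compound 2 `CCCCCC/C(=N\OC)c1cc(OC)c2c(c1OC)C(=O)C=CC2=O`; value > 10 ug/mL, a limit of the assay
- compound 3 `CCCCCC/C(=N\OCCC)c1cc(OC)c2c(c1OC)C(=O)C=CC2=O`; value > 10 ug/mL, a limit of the assay

Compound 3 stands only at a limit in this assay; the same holds for the two other values shown, and the limit of > 10 ug/mL in this assay, at which 3 of the 3 values shown sit, is the whole of what the series reports so far. For the measured compounds named here, the one step between compounds that differ in a single place, a step that the two limits leave unreadable from compound 2 to compound 3, is therefore of a size that cannot be read, since both ends are limits.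

Compound 4 `CCCCCCCCCO/N=C(\CCCCCC)c1cc(OC)c2c(c1OC)C(=O)C=CC2=O` is not yet measured. It differs from compound 3 by hexyl in place of hydrogen on a saturated chain carbon, three bonds along the chain from an oxygen on an unsaturated carbon.

Going by the values given here, no measured step bears directly on a change of this kind, and the only step, from a shorter to a longer chain at a different place, is unreadable. With every value of the series sitting at the limit, the expected step that the limit leaves unreadable from compound 3 to compound 4 from compound 3 to compound 4 is, for want of any readable precedent, not expected to move the value clear of that limit. Compound 4 is expected at 15 ug/mL in this assay, within a range from 4 ug/mL to 60 ug/mL, and most likely the assay again reports only a limit.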

Compound 4, concentration for half-maximal effect: > 10 ug/mL
Compound 4 ended at the assay's limit; the forecaster's own chance of this, stated with the estimate: 75%; the middle value lies beyond the limit too.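

In this assay compound 4 gives > 10 ug/mL, a limit of the assay, so the steps reaching it from compound 2 and compound 3 cannot be read. The series sits at a single limit: the limit of > 10 ug/mL in this assay, at which 4 of the 4 values shown sit.

The compounds shown leave open whether any chain on the shared core gives a value inside the assay's readable range.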